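Branching the ketone chain: from compound 2 to compound 3

The source may hold more compounds than are shown below. What is called first, only, known or untested is meant among the compounds shown, and "the series" means these compounds.

Compound 1 `Cc1c(OCCCCOc2ccc(C(=O)O)cc2)ccc(C(=O)CC2CCCC2)c1O` and compound 2 `CCC(=O)c1ccc(OCCCCOc2cc(C(=O)O)ccc2OC)c(C)c1O` have been measured in an assay on HEK293 cells for positive allosteric modulation of metabotropic glutamate receptor 2 (Rattus norvegicus), read by thallium flux, with a stated time of 2.5 min; on this read-out higher numbers stand for larger maximal responses and lower numbers for smaller maximal responses. Compound 1 gives 82.6% in this assay. Compound 2 gives 72.6% in this assay, the lower of the two numbers, though its gap to compound 1 lies within the scatter. Compound 3 `COc1ccc(C(=O)O)cc1OCCCCOc1ccc(C(=O)C(C)C)c(O)c1C` is unmeasured and differs from compound 2 by methyl in place of hydrogen on a saturated chain carbon bound to a carbonyl carbon and a saturated chain carbon. Among the measured compounds shown here, with no step between measured compounds to gauge this change, only a step within the scatter is expected, in no fixed direction. Compound 3 is estimated to give 75% in this assay, between 55% and 95%, an expected step of a number 2.4 percentage points higher from compound 2 to compound 3 (within the scatter).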

Compound 3, largest response reached (reported as percent of maximum), in percent of the reference or control that the assay uses: 66.6%
The estimate for compound 3 lay 8.4 percentage points above the measured number; the range from low to high includes it.
By their numbers in this assay, from the lowest: compounds 3, 2 and 1 (each within the scatter of the next, the first and the last beyond it).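

Ethyl to isopropyl on the ketone gives the first single-place step in the series: in this assay, the change reads a number 6 percentage points lower from compound 2 to compound 3 (within the scatter). At this saturated chain carbon bound to a carbonyl carbon and a saturated chain carbon, the added methyl therefore does not separate compound 2 from compound 3. No available data bear on the reason for this result.

Going by these compounds, whether a longer chain, a cyclopentyl group or an amine at this place would give a step beyond the scatter remains open.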